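Replacing bromo with hydroxy in compound 3

The compounds below may be only part of what the source reports. "The series", "measured", "known", "first", "only" and "open" are said of these compounds alone.

Of the compounds shown here, three sharing one core have been measured in a functional assay (mast cells) for inhibition, with Rattus norvegicus as the target; a higher number here means that more compound is needed for the effect, a lower number that less compound is needed. Compound 1 (`CC1CC/C(=N\Nc2cccc(Cl)c2)c2ncc(C(=O)O)c(=O)n21`) gives 311000 nM. Compound 2 (`CC1CC/C(=N\Nc2cccc(Br)c2)c2ncc(C(=O)O)c(=O)n21`) gives 6700 nM. Compound 3 (`CC1CC/C(=N\Nc2ccc(Br)cc2)c2ncc(C(=O)O)c(=O)n21`) gives 2000 nM, the lowest of the three numbers.

Compound 4 (`CC1CC/C(=N\Nc2ccc(O)cc2)c2ncc(C(=O)O)c(=O)n21`) has hydroxy in place of bromo on an aromatic carbon, para to a large group: hydroxy in place of bromo on an aromatic carbon.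

Among the measured compounds shown here, no measured step makes this exchange, and no compound tested so far lacks a halogen. The closest evidence is a 46-fold lower number from compound 1 to compound 2 (1.67 log units; beyond the scatter), with bromo in place of chloro, which shows that one substituent on the aromatic ring can matter greatly in this assay. Moving the bromo gave a smaller change, a 3.4-fold lower number from compound 2 to compound 3 (0.53 log units; beyond the scatter), while a 160-fold lower number from compound 1 to compound 3 (2.19 log units; beyond the scatter) combines both differences. The two lower numbers both belong to bromo compounds, so losing bromo is expected to raise the number, although three compounds make this a weak guide. The expected change is a moderate rise, a 5.0-fold higher number from compound 3 to compound 4 (0.70 log units; beyond the scatter), with wide uncertainty. For compound 4 the estimated value is 10000 nM, with an expected range of 1500 nM to 80000 nM.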

Compound 4, half-maximal effective concentration: 1300 nM
For compound 4 the middle estimate is 7.7-fold (0.89 log units) above the measured one; measured number below the stated range.
By their numbers in this assay, from the lowest: compounds 4 and 3 (each within the scatter of the next); then compound 2; then compound 1.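

At this position, para to a large group, the exchange of bromo for hydroxy adds a hydrogen-bond donor and a hydrogen-bond acceptor, yet in this assay the two compounds stay within the scatter of each other (a 1.5-fold lower number from compound 3 to compound 4 (0.19 log units; within the scatter)), so among these compounds a low number does not depend on a halogen on the aromatic ring. Compound 4 also extends the pattern seen with compound 3, in which both compounds with a 4-substituted phenyl have lower numbers than both with a 3-substituted phenyl: 4-hydroxyphenyl in place of 3-bromophenyl gives a modest step (a 5.2-fold lower number from compound 2 to compound 4 (0.71 log units; beyond the scatter)), and 4-hydroxyphenyl in place of 3-chlorophenyl gives a large one (a 240-fold lower number from compound 1 to compound 4 (2.38 log units; beyond the scatter)), although each of these steps changes both the group and its place on the ring. Nothing given here accounts for the closeness of hydroxy and bromo at this position.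

The compounds shown leave open whether a methoxy group, an amine or a plain hydrogen at this position would also give a number close to those of compound 3 and compound 4. They also leave open how 3-hydroxyphenyl would compare with 4-hydroxyphenyl, which would separate the effect of place from that of group for hydroxy.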